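A Halogenated Aryl Amide on a Core Without Activity

The source may report more compounds than this note shows. Statements on the series, on what has been measured and on what is new or still open speak of the compounds shown alone.

Compound 1 `O=C(Nc1ccc(Cl)c(-c2nnc3c(Cl)cccn23)c1)c1cccnc1` was examined in a functional assay on T47D cells (Homo sapiens) for antiproliferative activity, read by MTT assay, with a stated time of 72 h; on this read-out lower numbers stand for stronger inhibition and higher numbers for weaker inhibition. In this assay compound 1 reaches only the limit of > 100000 nM, which is a boundary of the measurement and not a number. Compound 2 `CS(=O)(=O)c1ccc(C(=O)Nc2ccc(Cl)c(-c3nnc4c(Cl)cccn34)c2)c(Cl)c1` shares the core of compound 1 and was run in the same assay; in this assay compound 2 likewise sits at the limit of > 100000 nM. Where compound 1 stands is therefore only a boundary, not a position on a scale, and the same holds for its one companion: the limit of > 100000 nM in this assay, at which 2 of the 2 values shown sit. Compound 3 `O=C(Nc1ccc(Cl)c(-c2nnc3c(Cl)cccn23)c1)c1c(F)cccc1Cl` differs from compound 1 in a single place: 2-chloro-6-fluorophenyl in place of pyridin-3-yl on a carbonyl carbon. For the measured compounds named here, no step between measured compounds exists, so nothing in these data says which way such a change moves the read-out in this assay. With both measured compounds at the limit, the expected step is a number no higher from compound 1 to compound 3 (the limit leaves the size open), no more than the usual scatter. Compound 3 is accordingly estimated at 100000 nM, with a range from 20000 nM to 300000 nM, and most likely the assay will again report only a limit.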

Compound 3, half-maximal inhibitory concentration: > 100000 nM
Compound 3 gave a limit, no number; the forecaster's own chance of this, stated with the estimate: 70%; the middle value sits exactly at the limit.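

In this assay compound 3 gives > 100000 nM as a limit of the assay and not a number. Compound 1 also stands at a limit, and the step from compound 1 to compound 3 cannot be read. The compounds shown leave open whether 2-chloro-6-fluorophenyl in place of pyridin-3-yl on a carbonyl carbon moves the read-out at all.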